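A few compounds are considered here, and "the series" means these few. Any claim that something is new, unique, unknown or untested is made for them only; others in the source may bear on it.

- Compound 1 `COc1ccc(/C=C/C(=O)c2ccc(OC)c3c2OC(C)(C)C=C3)c(F)c1`: 7560 nM
- Compound 2 `COc1ccc(C(=O)/C=C/c2ccccn2)c2c1C=CC(C)(C)O2`: 5760 nM

In a functional assay on HepG2 cells (Homo sapiens) for antiproliferative activity, read by MTT assay, with a stated time of 24 h (a higher number here means a weaker inhibitor, a lower number a stronger inhibitor), compound 2 gives 5760 nM, which lies within the scatter of compound 1 at 7560 nM, so the two cannot be ranked. Compound 3 `COc1ccc(C(=O)/C=C/c2ccccc2Cl)c2c1C=CC(C)(C)O2` differs from compound 2 in one place, with 2-chlorophenyl in place of pyridin-2-yl on a double-bonded chain carbon bound to a double-bonded chain carbon. For the measured compounds named here, only one measured step bears on this place: a 1.3-fold lower number from compound 1 to compound 2 (0.12 log units; within the scatter), where pyridin-2-yl replaced 2-fluoro-4-methoxyphenyl. Going by the values given here, that step stayed within the scatter, and it is the only evidence available, so no step beyond the scatter is expected in this assay. The expected change is a 1.1-fold higher number from compound 2 to compound 3 (0.05 log units; within the scatter). For compound 3 the estimated value is 6500 nM, with an expected range from 2800 nM to 15000 nM.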

Compound 3, half-maximal inhibitory concentration: > 10000 nM
Compound 3 was reported as a limit; the forecaster's own chance of this, stated with the estimate: 5%; at least 1.5-fold (0.18 log units) between middle value and limit.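

In this assay compound 3 carries a limit and not a number: the limit of > 10000 nM in this assay, at which 1 of the 3 values shown sits. At this place, 2-chlorophenyl in place of pyridin-2-yl gives an at least 1.7-fold higher number from compound 2 to compound 3 (0.23 log units; that floor lies within the scatter), and 2-chlorophenyl in place of 2-fluoro-4-methoxyphenyl gives an at least 1.3-fold higher number from compound 1 to compound 3 (0.12 log units; that floor lies within the scatter). The position has thus now produced a result that is no longer a plain number, but both steps are only floors, so the change cannot be sized and the three groups cannot be ranked on these data.

Going by these compounds, how far the true value of compound 3 lies past its limit remains open. Also open, on these data alone, is whether an unsubstituted phenyl, or a phenyl carrying an amine or a carboxylic acid, at this place would give a measurable number and separate itself from compound 2.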